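Compound 1 to compound 4: replacing benzyl(methyl)amino

The compounds below may be only part of what the source reports. "The series", "measured", "known", "first", "only" and "open" are said of these compounds alone.

Values in a physicochemical assay for lipophilicity (on this read-out higher numbers stand for higher lipophilicity and lower numbers for lower lipophilicity), for the compounds measured so far
- compound 1 `Cc1csc2cc([C@H](C)Nc3ncnc(N)c3C#N)c(-c3cccc(CN(C)CCCCN(C)Cc4ccccc4)c3)c(=O)n12` gives 2.2 (highest)
- compound 2 `Cc1csc2cc([C@H](C)Nc3ncnc(N)c3C#N)c(Cc3cccc(CN4CCC4)c3)c(=O)n12` gives 0.5 (lowest)
- compound 3 `Cc1csc2cc([C@H](C)Nc3ncnc(N)c3C#N)c(-c3cccc(CN4CCC(N(C)CCC(F)(F)F)CC4)c3)c(=O)n12` gives 1.1 (intermediate)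

Compound 1 stands highest of the three, beyond the scatter of both compound 3 and compound 2. The next compound to be read is compound 4 `Cc1csc2cc([C@H](C)Nc3ncnc(N)c3C#N)c(-c3cccc(CN(C)CCCCN4C[C@@H](C)O[C@@H](C)C4)c3)c(=O)n12`, which departs from compound 1 in one place. The change is 2,6-dimethylmorpholin-4-yl in place of benzyl(methyl)amino on a saturated chain carbon, four bonds along the chain from an amine nitrogen (2,6-dimethylmorpholin-4-yl in place of benzyl(methyl)amino, on a saturated chain carbon, four bonds along the chain from an amine nitrogen).

Among the compounds with values here, no measured pair isolates this change, so the expectation is loose. Only compound 1 carries benzyl(methyl)amino. Compound 3 lacks it and gives 1.1 (it differs elsewhere too), and compound 2 lacks it and gives 0.5 (it also differs elsewhere). In this assay a fall beyond the scatter is expected, estimated as a number 0.70 log units lower from compound 1 to compound 4 (beyond the scatter) (middle of the range). For compound 4 the estimate is 1.5 (expected range 1 to 2).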

Compound 4, distribution coefficient: 1.5
Compound 4: middle estimate and measured number agree at the digits printed; the range from low to high includes it.
By their numbers in this assay, from the lowest: compound 2; then compound 3; then compound 4; then compound 1.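

In this assay, the series now has its first step that differs in one place, and it reads a number 0.70 log units lower from compound 1 to compound 4 (beyond the scatter). The terminal group on this saturated chain carbon, four bonds along the chain from an amine nitrogen, therefore affects the read-out when 2,6-dimethylmorpholin-4-yl replaces benzyl(methyl)amino. This exchange removes the aromatic ring and adds a non-aromatic ring containing oxygen, and no available measurement offers an explanation for the step.

With these features changing together, the aromatic ring, the ring oxygen and the two methyl groups cannot be separated. Morpholin-4-yl without the methyl groups, piperidin-1-yl and benzyl(methyl)amino's saturated counterpart, cyclohexylmethyl(methyl)amino, would each isolate part of this change at the same chain carbon.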